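This account rests on a few compounds, and the source may have more. Where it says the series, first, only, none or still open, it means among the compounds named here.

Going by the values given here, in a functional assay on PC-3 cells (Homo sapiens) for antiproliferative activity, read by MTT assay, with a stated time of 24 h (on this read-out higher numbers stand for weaker inhibition and lower numbers for stronger inhibition), compound 1 `CCn1c(C(=O)N[C@H](C)CO)ccc1C(CC)(CC)c1ccc(OCS(=O)(=O)c2ccccc2)c(C)c1` gives 7790 nM and compound 2 `CCn1c(C(=O)N[C@@H](CO)C(C)C)ccc1C(CC)(CC)c1ccc(OCS(=O)(=O)c2ccccc2)c(C)c1` gives 10600 nM, so compound 2 stands within the scatter of the only other measured compound. Compound 3 `CCn1c(C(=O)NCCCO)ccc1C(CC)(CC)c1ccc(OCS(=O)(=O)c2ccccc2)c(C)c1` keeps the shared core and differs from compound 2 in a single place: 3-hydroxypropyl in place of 1-(hydroxymethyl)-2-methylpropyl on an amide-type nitrogen. Among the compounds with values here, one measured step bears on this change: a 1.4-fold higher number from compound 1 to compound 2 (0.13 log units; within the scatter), in which isopropyl replaces methyl on a saturated chain carbon bound to that kind of nitrogen. That step also alters the group on the amide-type nitrogen, and it stays within the scatter. It does not test an unbranched 3-hydroxypropyl chain, so the evidence is indirect. No shift beyond the scatter is therefore expected in this assay. The expected step is a 1.2-fold lower number from compound 2 to compound 3 (0.07 log units; within the scatter). The estimate for compound 3 is 9000 nM, with an expected range of 4500 nM to 18000 nM.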

Compound 3, half-maximal inhibitory concentration: 11300 nM
Compound 3: the middle estimate sits 1.3-fold (0.10 log units) below what was measured; low and high end bracket the measured number.
By their numbers in this assay, from the lowest: compounds 1, 2 and 3 (each within the scatter of the next).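

In this assay, replacing 1-(hydroxymethyl)-2-methylpropyl on the amide-type nitrogen with the unbranched 3-hydroxypropyl chain gives a 1.1-fold higher number from compound 2 to compound 3 (0.03 log units; within the scatter) and replacing 1-(hydroxymethyl)ethyl with it gives a 1.5-fold higher number from compound 1 to compound 3 (0.16 log units; within the scatter). The earlier step covered only a change in branch size, whereas these steps also remove the branch and the defined stereocentre from the group, and among compounds 1, 2 and 3 neither change moves the number beyond the scatter. Nothing shown accounts for how closely the three groups read.

As far as these compounds go, all three groups on this nitrogen carry a hydroxy group, so it remains open whether an amine, a carboxylic acid or a plain propyl chain would read the same. From the compounds shown here alone, it also remains open whether a longer hydroxyalkyl chain would stay within the scatter of these three compounds.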